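The source may report more compounds than this note shows. Statements on the series, on what has been measured and on what is new or still open speak of the compounds shown alone.

Measured in a functional assay on HUVEC cells (Homo sapiens), read by scintillation counting and thymidine incorporation, with a stated time of 24 h; a higher number here means a weaker inhibitor, a lower number a stronger inhibitor:
compound 1 `CCC(C)n1ncn(-c2ccc(N3CCN(c4ccc(OC[C@@H]5CO[C@@](CC)(c6ccc(Cl)cc6Cl)O5)cc4)CC3)cc2)c1=O` gives 353 nM
compound 2 `CCC(C)n1ncn(-c2ccc(N3CCN(c4ccc(OC[C@@H]5CO[C@@](CBr)(c6ccc(Cl)cc6Cl)O5)cc4)CC3)cc2)c1=O` gives 569 nM
compound 3 `CCC(C)n1ncn(-c2ccc(N3CCN(c4ccc(OC[C@@H]5CO[C@@](Cn6cnc(C)n6)(c6ccc(Cl)cc6Cl)O5)cc4)CC3)cc2)c1=O` gives 272 nM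

Compound 1 stands second highest of the three numbers in this assay; its nearest neighbour is compound 3 and its furthest compound 2, and both gaps are within the scatter. The two changes made so far both sit on the same saturated chain carbon bound to a saturated ring carbon: a 1.6-fold higher number from compound 1 to compound 2 (0.21 log units; within the scatter), a 1.3-fold lower number from compound 1 to compound 3 (0.11 log units; within the scatter), and a 2.1-fold lower number from compound 2 to compound 3 (0.32 log units; beyond the scatter). Compound 4 `CCC(C)n1ncn(-c2ccc(N3CCN(c4ccc(OC[C@@H]5CO[C@@](Cn6cc(C)nc6C)(c6ccc(Cl)cc6Cl)O5)cc4)CC3)cc2)c1=O` carries the change (2,4-dimethyl-1H-imidazol-1-yl in place of methyl on a saturated chain carbon bound to a saturated ring carbon). Among the measured compounds shown here, the step that bears on it most closely is the one to compound 3, where a five-membered aromatic ring with hetero atoms also entered at that place and the number stayed within the scatter. The bromo step went the other way, also within the scatter. Nothing among these three compounds suggests that a small aromatic ring on that chain carbon moves the number far in either direction, so the expected step is a 1.1-fold lower number from compound 1 to compound 4 (0.06 log units; within the scatter), with no change beyond the scatter. Compound 4 is therefore expected at 310 nM, in the range 150 nM to 700 nM.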

Compound 4, half-maximal inhibitory concentration: 492 nM
The estimate for compound 4 lay 1.6-fold (0.20 log units) below the measured number; the measured number falls inside the stated range.
By their numbers in this assay, from the lowest: compounds 3, 1, 4 and 2 (each within the scatter of the next, the first and the last beyond it).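

Notes on the series: in this assay, a second five-membered aromatic ring on the saturated chain carbon bound to a saturated ring carbon, here 2,4-dimethyl-1H-imidazol-1-yl, again leaves the number within the scatter of the methyl-bearing parent (a 1.4-fold higher number from compound 1 to compound 4 (0.14 log units; within the scatter)). Exchanging the 3-methyl-1H-1,2,4-triazol-1-yl of compound 3 for this ring gives no resolved difference (a 1.8-fold higher number from compound 3 to compound 4 (0.26 log units; within the scatter)), so the added hetero-ring comparison does not separate the two aromatic groups. Compound 4 also cannot be separated from the bromo compound (a 1.2-fold lower number from compound 2 to compound 4 (0.06 log units; within the scatter)), which leaves the step from bromo to 3-methyl-1H-1,2,4-triazol-1-yl as the only resolved difference at this place, and across these four groups the numbers stay in a narrow band. No measurement available here accounts for these numbers.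

From the compounds shown here alone, it remains open whether an aliphatic amine such as morpholine, a carboxylic acid or a longer alkyl chain on this carbon would move the number beyond the scatter. The unsubstituted imidazol-1-yl would be needed to show whether the methyl groups on the ring matter at all.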